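The source may hold more compounds than are shown below. What is called first, only, known or untested is meant among the compounds shown, and "the series" means these compounds.

Measured in a functional assay on HeLa cells (Homo sapiens) for antiproliferative activity, read by CCK-8 assay, with a stated time of 72 h; on this read-out lower numbers stand for stronger inhibition and higher numbers for weaker inhibition:
compound 1, `COc1ccc(C(=O)Nc2cccc(-c3oc4cc(-c5ccc(F)cc5)ccc4c(=O)c3O)c2)cc1`, 4820 nM
compound 2, `O=C(Nc1cccc(-c2oc3cc(-c4ccc(F)cc4)ccc3c(=O)c2O)c1)c1ccc(F)cc1F`, 10700 nM
compound 3, `COc1ccccc1C(=O)Nc1cccc(-c2oc3cc(-c4ccc(F)cc4)ccc3c(=O)c2O)c1`, 14100 nM

Compound 3 gives the highest of the three numbers: a 1.3-fold higher number from compound 2 to compound 3 (0.12 log units; within the scatter), which stays within the scatter, while a 2.9-fold higher number from compound 1 to compound 3 (0.47 log units; beyond the scatter) lies beyond it. For the measured compounds named here, the only compound whose number stands clearly apart is compound 1, with 4-methoxyphenyl on the carbonyl carbon; a 2.2-fold higher number from compound 1 to compound 2 (0.35 log units; beyond the scatter).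

Compound 4, `O=C(Nc1cccc(-c2oc3cc(-c4ccc(F)cc4)ccc3c(=O)c2O)c1)c1ccc(Br)cc1`, differs from compound 3 in one place: 4-bromophenyl in place of 2-methoxyphenyl on a carbonyl carbon. Going by the values given here, no measured step exchanges a methoxy-bearing phenyl for a bromine-bearing one, so the three steps bear on it only indirectly. They show that changing the aryl group on the carbonyl carbon moves the number by modest amounts, and that the 4-methoxyphenyl of compound 1 gives a lower number than the 2-methoxyphenyl of compound 3 (a 2.9-fold higher number from compound 1 to compound 3 (0.47 log units; beyond the scatter)). On that basis the number for compound 4 is expected to fall modestly, a 2.2-fold lower number from compound 3 to compound 4 (0.34 log units; beyond the scatter), with wide uncertainty. The estimate for compound 4 in this assay is 6500 nM, within 2800 nM to 15000 nM.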

Compound 4, half-maximal inhibitory concentration: 9740 nM
For compound 4 the middle estimate is 1.5-fold (0.18 log units) below the measured one; measured number inside the range.
By their numbers in this assay, from the lowest: compound 1; then compounds 4, 2 and 3 (each within the scatter of the next).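

In this assay, 4-bromophenyl on the carbonyl carbon does not separate from the two other groups already tested, with both steps within the scatter (a 1.4-fold lower number from compound 3 to compound 4 (0.16 log units; within the scatter); a 1.1-fold lower number from compound 2 to compound 4 (0.04 log units; within the scatter)). The step that does lie beyond the scatter is bromo in place of methoxy (a 2.0-fold higher number from compound 1 to compound 4 (0.31 log units; beyond the scatter)), so among these four compounds the lowest number goes with 4-methoxyphenyl in particular, and 4-bromophenyl does not share it. No supporting data on hand explain this difference.

Still open, going by these compounds, is whether the lower number of compound 1 extends to 4-ethoxyphenyl or 4-(dimethylamino)phenyl on the same carbonyl carbon. Also open, on these data alone, is how a carboxylic acid on this phenyl ring, or a saturated alkyl chain replacing the ring, would read in this assay on the shared core.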